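Mirror image of compound 3: expected binding

The source may report more compounds than this note shows. Statements on the series, on what has been measured and on what is new or still open speak of the compounds shown alone.

Measured compounds:
compound 1 `CC(C)(C)[C@@]1(c2ccccc2)OCC[C@@H](CCN)O1` — > 10000 nM
compound 2 `C[C@@]1(c2ccccc2)OCC[C@@H](CCN)O1` — > 10000 nM
compound 3 `NCC[C@H]1CCO[C@@H](c2ccccc2)O1` — > 10000 nM

Three compounds of the series have been run in an assay on brain for displacement of a labelled ligand from Sigma non-opioid intracellular receptor 1 (Cavia porcellus); on this read-out lower numbers stand for stronger inhibition and higher numbers for weaker inhibition. Compound 1 gives > 10000 nM, which is a limit of the assay and not a number. Compound 2 gives > 10000 nM, again a limit. The step that the two limits leave unreadable from compound 1 to compound 2 is therefore unreadable. Compound 3 gives > 10000 nM, also a limit. Compound 3 thus sits at the limit of > 10000 nM in this assay, at which 3 of the 3 values shown sit, with nothing in the numbers to separate it from the other two.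

Compound 4 `NCC[C@@H]1CCO[C@H](c2ccccc2)O1` remains to be measured. It differs from compound 3 in that (the two compounds have the same atoms and bonds and differ only in configuration as drawn: 2 of 2 stereo elements differ (all stereocentres are inverted: mirror images); a stereocentre at a saturated ring carbon is drawn S in compound 3 and R in compound 4; a stereocentre at a saturated ring carbon is drawn R in compound 3 and S in compound 4). Within the data shown here, no measured step in the set bears on a change of configuration alone, and the only recorded step, a step that the two limits leave unreadable from compound 1 to compound 2, is itself unreadable because of the limit of > 10000 nM in this assay, at which 3 of the 3 values shown sit. The expectation for compound 4 in this assay rests solely on compound 3 standing at > 10000 nM. Compound 4 is therefore expected at 15000 nM, with a range of 3000 nM to 60000 nM, most probably reported again as a limit. The step that the limit leaves unreadable from compound 3 to compound 4 is expected to lie within the scatter, in no readable direction.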

Compound 4, inhibition constant: > 10000 nM
Compound 4: only a limit was reported (the forecaster's own chance of this, stated with the estimate: 75%); the middle value does not contradict the limit.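

In this assay compound 4 gives > 10000 nM, a limit of the assay and not a number. Among these compounds, no step from compound 1, compound 2 or compound 3 to compound 4 can be read: the limit of > 10000 nM in this assay, at which 4 of the 4 values shown sit. Still open, going by these compounds, is whether the mirror images compound 3 and compound 4 differ at all, and how far any of the four compounds lies beyond that limit.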